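Swapping the amine substituent on the trifluoromethylpyridine core

This account rests on a few compounds, and the source may have more. Where it says the series, first, only, none or still open, it means among the compounds named here.

Measured compounds:
Compound 1 `CCCCNc1nc(C(F)(F)F)ccc1CNC(=O)C(C)c1ccc(NS(C)(=O)=O)c(F)c1` gives 9.1 nM in a functional assay on CHO-K1 cells for antagonist activity at transient receptor potential cation channel subfamily V member 1 (Homo sapiens), read by FLIPR; on this read-out lower numbers stand for stronger inhibition and higher numbers for weaker inhibition.
Compound 2 `Cc1ccc(Nc2nc(C(F)(F)F)ccc2CNC(=O)C(C)c2ccc(NS(C)(=O)=O)c(F)c2)cc1C` gives 39.3 nM in this assay.
Compound 3 `CC(C(=O)NCc1ccc(C(F)(F)F)nc1N(C)c1ccccc1)c1ccc(NS(C)(=O)=O)c(F)c1` gives 0.9 nM in this assay.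

Compound 3 stands lowest of the three, and both of its steps from the other compounds are beyond the scatter, so it is the most potent of the measured set. The step is a 10-fold lower number from compound 1 to compound 3 (1.00 log units; beyond the scatter) and a 44-fold lower number from compound 2 to compound 3 (1.64 log units; beyond the scatter), while between the two weaker compounds it is a 4.3-fold higher number from compound 1 to compound 2 (0.64 log units; beyond the scatter).

Compound 4 `CC(C(=O)NCc1ccc(C(F)(F)F)nc1N1CCC(c2ccccc2)CC1)c1ccc(NS(C)(=O)=O)c(F)c1` has not yet been measured. It differs from compound 3 in one place: 4-phenylpiperidin-1-yl in place of methyl(phenyl)amino on an aromatic carbon.

Of the measured steps, the two that end at compound 3 bear on this change, since each replaces the group on the same aromatic carbon. Both were modest or large, and in each case the methyl(phenyl)amino group gave the lowest number. The entering 4-phenylpiperidin-1-yl group resembles none of the three groups already tried, so the direction is uncertain; the nearest guide is that every group other than methyl(phenyl)amino gave a higher number. A modest step upward in this assay is therefore expected, roughly a 6.7-fold higher number from compound 3 to compound 4 (0.82 log units; beyond the scatter). Compound 4 is estimated at 6 nM, with a range from 1 nM to 40 nM.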

Compound 4, inhibition constant: 0.6 nM
Compound 4: middle estimate off by 10-fold (1.00 log units), on the high side; measured number below the stated range.
By their numbers in this assay, from the lowest: compounds 4 and 3 (each within the scatter of the next); then compound 1; then compound 2.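

Within the data shown here, on this aromatic carbon next to the ring nitrogen, methyl(phenyl)amino is not the only group that gives a low number in this assay: the larger 4-phenylpiperidin-1-yl, which adds a six-membered non-aromatic ring, cannot be told apart from it, with a 1.5-fold lower number from compound 3 to compound 4 (0.18 log units; within the scatter) standing as the step. Compound 4 also stands well clear of the other two compounds, with a 15-fold lower number from compound 1 to compound 4 (1.18 log units; beyond the scatter) and a 66-fold lower number from compound 2 to compound 4 (1.82 log units; beyond the scatter) as its steps, so among these four the two groups whose attached nitrogen carries no hydrogen give lower numbers than the two whose nitrogen does, and no compound goes against this. Nothing available here explains why the numbers fall this way.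

The compounds shown leave open whether the phenyl ring of the new group matters at all, since a plain piperidin-1-yl or a morpholin-4-yl group on this carbon would be needed to separate the ring from its phenyl. They also leave open whether the hydrogen on the nitrogen is what counts, a question that a methyl(butyl)amino group on the same carbon could address.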